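A few compounds are considered here, and "the series" means these few. Any claim that something is new, unique, unknown or untested is made for them only; others in the source may bear on it.

Measured compounds:
- Compound 1, `Fc1ccc(/C=N/NC(=S)Nc2nc3ccc(Cl)cc3s2)cc1`: 30 mg/kg
- Compound 2, `S=C(N/N=C/c1ccc(Cl)cc1)Nc1nc2ccc(Cl)cc2s1`: 300 mg/kg

In a functional assay on the whole organism with Mus musculus as the target, in the maximal electroshock model, with a stated time of 0.5 h (a lower number here means that less compound is needed, a higher number that more compound is needed for the effect), compound 1 gives 30 mg/kg and compound 2 gives 300 mg/kg. Compound 2 thus stands highest of the two numbers measured, its nearest neighbour being compound 1, which differs only by a 10-fold higher number from compound 1 to compound 2 (1.00 log units; beyond the scatter). Compound 3, `S=C(N/N=C/c1ccccc1Cl)Nc1nc2ccc(Cl)cc2s1`, has not been measured. It differs from compound 2 by 2-chlorophenyl in place of 4-chlorophenyl on a carbon with a double bond to nitrogen. Going by the values given here, no measured step concerns a move of a substituent around a ring; the single step known, from fluoro to chloro, speaks to a different kind of change and gives no direction for this one. The expectation for compound 3 therefore rests on compound 2 alone, with a wide range and a real chance that the assay returns only a limit. Compound 3 is expected to give about 300 mg/kg, between 100 mg/kg and 1000 mg/kg, which is estimated as no change at the digits printed from compound 2 to compound 3 (within the scatter).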

Compound 3, minimum effective dose: 300 mg/kg
For compound 3 middle estimate and measured number coincide at the digits printed; the measured number falls inside the stated range.
By their numbers in this assay, from the lowest: compound 1; then compounds 2 and 3 (each within the scatter of the next).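

Moving the chlorine around the phenyl ring leaves the result unchanged in this assay, with no change at the digits printed from compound 2 to compound 3 (within the scatter), so at this carbon with a double bond to nitrogen, 2-chlorophenyl and 4-chlorophenyl cannot be told apart. The comparison with the fluoro compound holds for this second chlorinated isomer too, with a 10-fold higher number from compound 1 to compound 3 (1.00 log units; beyond the scatter), and both chlorophenyl compounds stand apart from 4-fluorophenyl in the same way. Nothing available here bears on why the numbers fall as they do.

The compounds shown leave open whether the insensitivity to the chlorine's place extends to fluoro, since 4-fluorophenyl is the only fluorinated case. They also do not tell how the assay would read with a methoxy group, an amine or a carboxylic acid on the phenyl ring in place of the halogen.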